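The source may hold more compounds than are shown below. What is called first, only, known or untested is meant among the compounds shown, and "the series" means these compounds.

Measured so far in a functional assay on the whole organism (strain Jcl:Sprague-Dawley) for inhibition, with Rattus norvegicus as the target, with stated times of 3 min and 3 h, at a dose of 1 mg/kg by the intravenous route; on this read-out higher numbers stand for more inhibition at the one dose given (going by the name of the read-out) and lower numbers for less inhibition:
compound 1, `CNCc1cc(-c2cccnc2F)n(S(=O)(=O)c2ccsc2)c1`, gives 98%;
compound 2, `CNCc1cc(-c2cccnc2F)n(S(=O)(=O)c2cccs2)c1`, gives 96%;
compound 3, `CNCc1cn(S(=O)(=O)c2ccco2)c(-c2cccnc2F)c1F`, gives 75%.

On these numbers compound 3 stands lowest of the three, with compound 2 nearest and compound 1 furthest, both gaps beyond the scatter. Compound 4, `CNCc1cn(S(=O)(=O)c2cccc(OC)n2)c(-c2cccnc2F)c1F`, differs from compound 3 in one place: 6-methoxypyridin-2-yl in place of furan-2-yl on a sulfonyl sulfur. Among the measured compounds shown here, the only measured step that touches the same place is the exchange of one ring on the sulfonyl sulfur for another, a number 2 percentage points lower from compound 1 to compound 2 (within the scatter), which stayed within the scatter. That step, however, swapped two closely related five-membered rings, whereas here a six-membered ring with a methoxy group enters, so the guidance is thin. The expected step is therefore no change at the digits printed from compound 3 to compound 4 (within the scatter), with a wide range. Compound 4 is estimated at 75%, between 50% and 95%.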

Compound 4, a percentage reported as inhibition, in the whole organism at one dose (the size of the read-out at that dose, not a potency): 98%
Compound 4: middle estimate off by 23 percentage points, on the low side; the measured number lies above the stated range.
By their numbers in this assay, from the lowest: compound 3; then compounds 2, 1 and 4 (each within the scatter of the next).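

In this assay, putting 6-methoxypyridin-2-yl in place of furan-2-yl on the sulfonyl sulfur gives a number 23 percentage points higher from compound 3 to compound 4 (beyond the scatter). Among the compounds shown here, the earlier step at this position, a number 2 percentage points lower from compound 1 to compound 2 (within the scatter), showed no change beyond the scatter, so this is the first sign that the ring on the sulfur can matter. No measurement here explains the rise.

The compounds shown do not separate the part played by the methoxy group from that of the six-membered ring. A plain pyridin-2-yl or phenyl ring on the same sulfur would help tell these apart.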